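The compounds below may be only part of what the source reports. "The series", "measured", "known", "first", "only" and "open" are said of these compounds alone.

Measured so far in a functional assay on HeLa cells (Homo sapiens) for cytotoxicity, read by MTT assay, with a stated time of 48 h; a higher number here means a weaker inhibitor, a lower number a stronger inhibitor

- compound 1 `Cc1n[nH]c2c1C(c1ccc(N(C)C)cc1)C(C(=O)n1ncc(C#N)c1N)=C(N)N2` gives 60200 nM
- compound 2 `Cc1n[nH]c2c1C(c1ccc(N(C)C)cc1)C(C(=O)NNc1cc([N+](=O)[O-])ccc1[N+](=O)[O-])=C(N)N2` gives 8520 nM
- compound 3 `Cc1n[nH]c2c1C(c1ccc(N(C)C)cc1)C(C(=O)N/N=C1/C(=O)Nc3ccccc31)=C(N)N2` gives 52900 nM

Compound 1 and compound 3 lie within the scatter of each other at the upper end of these numbers. Compound 2 lies beyond the scatter from compound 1, with a lower number.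

The next compound is compound 4 `Cc1n[nH]c2c1C(c1ccc(N(C)C)cc1)C(C(=O)O)=C(N)N2`. It keeps the core of compound 1 and has hydroxy in place of 5-amino-4-cyano-1H-pyrazol-1-yl on a carbonyl carbon. The (5-amino-4-cyano-1H-pyrazol-1-yl)carbonyl group thus becomes carboxy.

Going by the values given here, no two measured compounds differ in one place only, so no measured step bears directly on this change. Among the compounds with values here, the only guide is the spread of the three values. Compound 3 (52900 nM) sits level with compound 1 despite a different group on the carbonyl, whereas compound 2 (8520 nM) goes against any reading that this group leaves the number unchanged.

In this assay, no step beyond the scatter is expected, and the wide range allows for the thin evidence. The estimated 1.2-fold lower number from compound 1 to compound 4 (0.08 log units; within the scatter) stays within the scatter. The expected value for compound 4 is 50000 nM, with an estimated range from 18000 nM to 120000 nM.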

Compound 4, half-maximal inhibitory concentration: 33600 nM
Beside the measured number, compound 4's estimate is 1.5-fold (0.17 log units) above it, and the stated range covers the measured number.
By their numbers in this assay, from the lowest: compound 2; then compounds 4, 3 and 1 (each within the scatter of the next).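

In this assay, going by these compounds alone, the first single-place step at this position, hydroxy in place of 5-amino-4-cyano-1H-pyrazol-1-yl on a carbonyl carbon, gives a 1.8-fold lower number from compound 1 to compound 4 (0.25 log units; within the scatter) and so leaves the two compounds level. The change removes a group of 8 heavy atoms, with its five-membered aromatic ring and its nitrile, and puts a single oxygen-based group in its place, yet for this pair the number does not move beyond the scatter; the pyrazolyl group is therefore not required to reach the level of compound 1 in this assay. No measurement shown gives a reason for this level outcome.

Within the data shown here, open is whether a methoxy group or a plain amino group on the same carbonyl carbon would also stay level with compound 4, since one pair shows only one exchange at this position. Also open is whether the number of compound 2, 8520 nM, traces to its group on the carbonyl, as no compound shown differs from it in one place only.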